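Lengthening the triazole chain: from ethyl to butyl

The compounds below may be only part of what the source reports. "The series", "measured", "known", "first", "only" and "open" are said of these compounds alone.

Of the compounds shown here, three from the same series have been measured in a functional assay on RAW264.7 cells (Mus musculus) for inhibition, read by Griess assay, with stated times of 2 h and 24 h; on this read-out higher numbers stand for weaker inhibition and lower numbers for stronger inhibition. Compound 1 `CCn1cc(COc2cc(O)c3c(c2)O[C@H](c2ccc(OC)c(O)c2)C/C3=N\O)nn1` gives 3140 nM. Compound 2 `C#CCOc1cc(O)c2c(c1)O[C@H](c1ccc(OC)c(O)c1)CC2=O` gives 20900 nM. Compound 3 `COc1ccc([C@@H]2CC(=O)c3c(O)cc(OCc4cn(Cc5cccc(Cl)c5)nn4)cc3O2)cc1O` gives 18200 nM. Among these three numbers compound 1 stands lowest, and its distance to both compound 2 and compound 3 lies beyond the usual scatter, so compound 1 is the strongest inhibitor of the three.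

Compound 4 `CCCCn1cc(COc2cc(O)c3c(c2)O[C@H](c2ccc(OC)c(O)c2)C/C3=N\O)nn1` has not yet been measured. It differs from compound 1 in one place: ethyl in place of hydrogen on a saturated chain carbon, two bonds along the chain from an aromatic nitrogen. Within the data shown here, no measured pair in this set shows the same kind of change, so there is no direct precedent for its size or direction. With only the chain made longer and nothing else altered, the step from compound 1 to compound 4 is expected to be small, most likely within the scatter, and a 1.1-fold lower number from compound 1 to compound 4 (0.05 log units; within the scatter) is the estimate. In this assay compound 4 is therefore expected to give about 2800 nM, with a range from 900 nM to 9000 nM.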

Compound 4, half-maximal inhibitory concentration: 8900 nM
The estimate for compound 4 lay 3.2-fold (0.50 log units) below the measured number; the measured number falls inside the stated range.
By their numbers in this assay, from the lowest: compound 1; then compound 4; then compounds 3 and 2 (each within the scatter of the next).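

Among these compounds, this is the first pair in the set that differs only in this chain, and it shows that the position responds to chain length. In this assay the change from ethyl to butyl gives a 2.8-fold higher number from compound 1 to compound 4 (0.45 log units; beyond the scatter) and so weaker inhibition, a modest loss that goes beyond the usual scatter. Nothing measured here offers an explanation for this loss.

As far as these compounds go, a single step between two chain lengths does not make a trend, so it remains open whether a propyl chain would land between these two numbers, or whether a methyl group or a longer hexyl chain would continue the same direction. From the compounds shown here alone, it is also open how this position would respond to a chain ending in an amine or a carboxylic acid.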